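Extending the chain of compound 2

A few compounds are considered here, and "the series" means these few. Any claim that something is new, unique, unknown or untested is made for them only; others in the source may bear on it.

In a functional assay on HeLa cells (Homo sapiens) for antiproliferative activity (on this read-out lower numbers stand for stronger inhibition and higher numbers for weaker inhibition), compound 1 `C/C1=C\[C@@H](O)C(=O)/C=C/C=C/c2csc(n2)[C@@H](C)N2C(=O)C[C@@]([C@@](C)(O)C(=O)SCc3oc(=O)oc3C)(CC1)[S+]2[O-]` gives 4.6 nM. Compound 2 `COCCOCCOCC(=O)O[C@@H]1/C=C(\C)CC[C@]2([C@@](C)(O)C(=O)SCc3oc(=O)oc3C)CC(=O)N([C@H](C)c3nc(cs3)/C=C/C=C/C1=O)[S+]2[O-]` gives 5.5 nM, and these two numbers lie within the scatter of each other, so compound 2 stands level with compound 1 on the data so far.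

Compound 3 `COCCOCCOCCOCCOCCOCC(=O)O[C@@H]1/C=C(\C)CC[C@]2([C@@](C)(O)C(=O)SCc3oc(=O)oc3C)CC(=O)N([C@H](C)c3nc(cs3)/C=C/C=C/C1=O)[S+]2[O-]` extends the chain of compound 2: (2-(2-methoxyethoxy)ethoxy)methyl in place of hydrogen on a saturated chain carbon bound to an oxygen on a saturated carbon. This is (2-(2-methoxyethoxy)ethoxy)methyl in place of hydrogen on a saturated chain carbon bound to an oxygen on a saturated carbon.

Among the measured compounds shown here, only one measured step bears on this change: a 1.2-fold higher number from compound 1 to compound 2 (0.08 log units; within the scatter), where a chain without a ring replaced a hydrogen on an oxygen on a saturated carbon. That step stayed within the scatter, but it is a single precedent.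

In this assay the expected step is a 1.2-fold higher number from compound 2 to compound 3 (0.07 log units; within the scatter), with nothing expected beyond the scatter. For compound 3 the estimate is 6.5 nM, with an expected range of 3 nM to 14 nM.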

Compound 3, half-maximal inhibitory concentration: 43 nM
Compound 3: middle estimate off by 6.6-fold (0.82 log units), on the low side, outside the stated range (above it).
By their numbers in this assay, from the lowest: compounds 1 and 2 (each within the scatter of the next); then compound 3.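

This position does not accept every chain: in this assay the further extension gives a 7.8-fold higher number from compound 2 to compound 3 (0.89 log units; beyond the scatter) and so moves the number beyond the scatter, while the earlier step of a 1.2-fold higher number from compound 1 to compound 2 (0.08 log units; within the scatter) stayed within it. Across these three compounds, the chain tolerated in compound 2 is therefore no guide to the longer chain of compound 3, and chain length at this position has to be treated as a variable in its own right. No measurement at hand accounts for this step.

Two chains alone cannot show whether the number climbs steadily with length or jumps past a certain length, and a chain of intermediate length would help settle that. On these data alone, how a still longer chain, or a chain ending in an amine or a carboxylic acid, would read here remains open.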